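Bromo for Chloro Across Two Salicylanilide-Type Cores

The source may hold more compounds than are shown below. What is called first, only, known or untested is meant among the compounds shown, and "the series" means these compounds.

Compound 1 `O=C(Oc1ccc(Cl)cc1C(=O)Nc1ccc(C(F)(F)F)cc1)c1cnc(Cl)cn1` and compound 2 `O=C(Oc1ccc(Br)cc1C(=O)Nc1ccc(C(F)(F)F)cc1)c1cnc(Cl)cn1` share one core and differ by bromo in place of chloro on an aromatic carbon. In a physicochemical assay for solubility, read by spectrophotometry (on this read-out lower numbers stand for lower solubility and higher numbers for higher solubility), compound 1 gives < 100000 nM, which is a limit of the assay rather than a number. In this assay compound 2 gives < 100000 nM, again only a limit. The step that the two limits leave unreadable from compound 1 to compound 2 therefore cannot be sized, since both values sit at the limit of < 100000 nM in this assay, at which 2 of the 3 values shown sit. Compound 3 `O=C(NCCCCl)Oc1ccc(Cl)cc1C(=O)Nc1ccc(Cl)c(Cl)c1` has a different core, and the difference between the two cores is not broken down here. In this assay compound 3 gives < 50000 nM, a limit, the one at the limit of < 50000 nM in this assay, at which 1 of the 3 values shown sits. Compound 4 `O=C(NCCCCl)Oc1ccc(Br)cc1C(=O)Nc1ccc(Cl)c(Cl)c1` is not yet measured and differs from compound 3 by bromo in place of chloro on an aromatic carbon, the same kind of change as in the first pair, although the place is para to a ((3-chloropropyl)carbamoyl)oxy group rather than para to a ((5-chloropyrazin-2-yl)carbonyl)oxy group. Because the step that the two limits leave unreadable from compound 1 to compound 2 is unreadable, the step from compound 3 to compound 4 is expected to be small, a step that the limit leaves unreadable from compound 3 to compound 4, and most likely to return another limit. Compound 4 is estimated at 20000 nM, between 3000 nM and 50000 nM.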

Compound 4, solubility: < 50000 nM
Compound 4: a limit, no number; the forecaster's own chance of this, stated with the estimate: 80%; the middle value lies beyond the limit too.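

For the compounds shown here, compound 3 and compound 4 both return only a limit in this assay, so no step between them can be read. The compounds shown leave open how large any step from chloro to bromo is on either core.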